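From methoxymethoxy to a triazolyl group at one site

The source may report more compounds than this note shows. Statements on the series, on what has been measured and on what is new or still open speak of the compounds shown alone.

Working notes on a series sharing the core of compound 1 `CC(=O)OC/C1=C/C[C@](C)(CCC=C(C)C)/C=C/[C@@H](OC(=O)C=C(C)C)[C@](C)(O)/C=C/C1=O`, alongside compound 2 `CC[Si](CC)(CC)C/C1=C/C[C@](C)(CCC=C(C)C)/C=C/[C@@H](OC(=O)C=C(C)C)[C@](C)(O)/C=C/C1=O` and compound 3 `COCOC/C1=C/C[C@](C)(CCC=C(C)C)/C=C/[C@@H](OC(=O)C=C(C)C)[C@](C)(O)/C=C/C1=O`. In a functional assay on SW480 cells (Homo sapiens) for antiproliferative activity, read by MTT assay, with a stated time of 48 h (on this read-out higher numbers stand for weaker inhibition and lower numbers for stronger inhibition), compound 1 gives 2950 nM and compound 2 gives 2690 nM. Compound 3 gives 3710 nM, which lies within the scatter of both other values.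

The next compound is compound 4 `CC(C)=CCC[C@]1(C)/C=C/[C@@H](OC(=O)C=C(C)C)[C@](C)(O)/C=C/C(=O)/C(Cn2cc(CO)nn2)=C\C1`, with the change (4-(hydroxymethyl)-1H-1,2,3-triazol-1-yl in place of methoxymethoxy on a saturated chain carbon bound to a double-bonded ring carbon). In words, this places 4-(hydroxymethyl)-1H-1,2,3-triazol-1-yl in place of methoxymethoxy on a saturated chain carbon bound to a double-bonded ring carbon.

Within the data shown here, three measured steps bear on this site: a 1.1-fold lower number from compound 1 to compound 2 (0.04 log units; within the scatter), a 1.3-fold higher number from compound 1 to compound 3 (0.10 log units; within the scatter) and a 1.4-fold higher number from compound 2 to compound 3 (0.14 log units; within the scatter). All three stay within the scatter, so the measured groups at this site show no separation in this assay. None of those groups holds an aromatic ring, however, so the data do not test the entering group directly.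

On these steps, no change beyond the scatter is expected in either direction, though the uncertainty is wide. The expected step is a 1.2-fold lower number from compound 3 to compound 4 (0.09 log units; within the scatter). For compound 4 the estimated value is 3000 nM, with an expected range from 1100 nM to 8000 nM.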

Compound 4, half-maximal inhibitory concentration: 2870 nM
Compound 4: middle estimate off by 1.0-fold (0.02 log units), on the high side, within the range that was stated.
By their numbers in this assay, from the lowest: compounds 2, 4, 1 and 3 (each within the scatter of the next).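

In this assay, the saturated chain carbon bound to a double-bonded ring carbon now carries a group with a five-membered aromatic ring with 3 hetero atoms, and the number stays within the scatter of every earlier compound: against methoxymethoxy (a 1.3-fold lower number from compound 3 to compound 4 (0.11 log units; within the scatter)), against the silicon-bearing group of compound 2 (a 1.1-fold higher number from compound 2 to compound 4 (0.03 log units; within the scatter)) and against acetoxy (a 1.0-fold lower number from compound 1 to compound 4 (0.01 log units; within the scatter)). The four groups now measured at this place, with and without an aromatic ring, show no separation, so the lack of separation among compound 1, compound 2 and compound 3 now extends to a ring-bearing group, which those three could not test. No measurement at hand accounts for this lack of separation.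

As far as these compounds go, whether it persists with an amine or a carboxylic acid at this place remains open, as does the outcome of a longer chain in place of the hydroxymethyl on the 4-(hydroxymethyl)-1H-1,2,3-triazol-1-yl group. Whether these four compounds also stay together outside this assay is open as well.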